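Aryl substitution on the ring amide nitrogen

This account rests on a few compounds, and the source may have more. Where it says the series, first, only, none or still open, it means among the compounds named here.

Within the data shown here, compound 2 `O=C(NCCCCc1ccccc1)c1cccc(C2SCC(=O)N2c2cccc(F)c2)c1` gives the higher of the two numbers measured so far in a functional assay on HOS cells (Homo sapiens) for inhibition, read by CCK-8 assay, with a stated time of 72 h, tested at 1 uM (a lower number here means less inhibition, a higher number more inhibition at the concentration tested (going by the name of the read-out)), with 84%. Compound 1 `COc1ccc(F)cc1N1C(=O)CSC1c1cccc(C(=O)NCCCCc2ccccc2)c1`, which carries a methoxy on the aromatic ring attached to the ring nitrogen, gives 46% in this assay. Among the measured compounds shown here, the one step measured between these two, a number 38 percentage points higher from compound 1 to compound 2 (beyond the scatter), shows that removing the methoxy from that aromatic ring went with a much higher read-out.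

Compound 3 `COc1cccc(OC)c1N1C(=O)CSC1c1cccc(C(=O)NCCCCc2ccccc2)c1` is not yet measured. Relative to compound 2 the change is 2,6-dimethoxyphenyl in place of 3-fluorophenyl on an amide-type nitrogen in a ring. For the measured compounds named here, this is the step that bears on it: the single measured step from compound 1 to compound 2 was large, in the direction of more inhibition on loss of a methoxy, and compound 3 reintroduces methoxy, twice, on the same aromatic ring while giving up the fluorine. A step of comparable size in the opposite direction is therefore expected in this assay, a number 49 percentage points lower from compound 2 to compound 3 (beyond the scatter). Compound 3 is estimated to give 35%, within a range of 10% to 62%, because compound 1 with one methoxy already sat at 46%.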

Compound 3, a percentage reported as inhibition, at one concentration (the size of the read-out at that concentration, not a potency): 80%
Compound 3: the middle estimate sits 45 percentage points below what was measured; measured number outside the range, above it.
By their numbers in this assay, from the lowest: compound 1; then compounds 3 and 2 (each within the scatter of the next).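

At the amide-type nitrogen in the ring, methoxy on the aromatic ring does not by itself go with a low read-out in this assay: the 2,6-dimethoxyphenyl group of compound 3 and the 3-fluorophenyl group of compound 2 give numbers within the scatter of each other (a number 4 percentage points lower from compound 2 to compound 3 (within the scatter)). The other new step (a number 34 percentage points higher from compound 1 to compound 3 (beyond the scatter)) shows that a change confined to this aromatic ring can restore most of what the 5-fluoro-2-methoxyphenyl group of compound 1 lacks, so among these three compounds, compound 1 alone stands apart, and compound 3 goes against any simple rule that methoxy lowers the number. No supporting measurement bears on why these substituents behave this way.

The compounds shown leave open whether the low number of compound 1 comes from the methoxy and fluorine together on one ring or from how they are placed, and a comparison with an unsubstituted phenyl at this nitrogen would help to separate the two. They also leave open how an aromatic ring carrying an amine or a carboxylic acid would read, and each number here is the size of the read-out at one concentration, not a potency.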